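From 2-chlorophenyl to 3-chlorophenyl: an expected quiet step

A few compounds are considered here, and "the series" means these few. Any claim that something is new, unique, unknown or untested is made for them only; others in the source may bear on it.

In a toxicity assay on MT4 cells (Homo sapiens) for cytotoxicity, read by MTT assay (on this read-out higher numbers stand for lower toxicity in this test and lower numbers for higher toxicity in this test), compound 1 `Cc1cc(-c2ccccc2)cc(C)c1Oc1cc(N)nc(Nc2ccc(C#N)cc2)n1` gives 25600 nM as its reading, compound 2 `Cc1cc(-c2cccc(F)c2)cc(C)c1Oc1cc(N)nc(Nc2ccc(C#N)cc2)n1` gives 24700 nM as its reading, and compound 3 `Cc1cc(-c2ccccc2Cl)cc(C)c1Oc1cc(N)nc(Nc2ccc(C#N)cc2)n1` gives 25100 nM on the same scale. Compound 3 thus stands level with the other two, and its readings cannot be told apart from theirs.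

Compound 4 `Cc1cc(-c2cccc(Cl)c2)cc(C)c1Oc1cc(N)nc(Nc2ccc(C#N)cc2)n1` has yet to be measured. Its difference from compound 3 is 3-chlorophenyl in place of 2-chlorophenyl on an aromatic carbon and amounts to 3-chlorophenyl in place of 2-chlorophenyl on an aromatic carbon, meta to two methyl groups and para to a large group.

For the measured compounds named here, no measured step makes this exact change, but three bear on it. Fluoro in place of hydrogen gave a 1.0-fold lower number from compound 1 to compound 2 (0.02 log units; within the scatter) in this series, chloro in place of hydrogen gave a 1.0-fold lower number from compound 1 to compound 3 (0.01 log units; within the scatter) in the same series, and 2-chlorophenyl in place of 3-fluorophenyl gave a 1.0-fold higher number from compound 2 to compound 3 (0.01 log units; within the scatter) on that scale. None of these steps leaves the scatter, so no step beyond the scatter is expected here, and no direction can be favoured. The estimate is a 1.0-fold lower number from compound 3 to compound 4 (0.00 log units; within the scatter) for this change. In this assay compound 4 is expected at 25000 nM, within an estimated range of 16000 nM to 38000 nM for that value.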

Compound 4, half-maximal cytotoxic concentration: 22300 nM
For compound 4 the middle estimate is 1.1-fold (0.05 log units) above the measured one, and the stated range covers the measured number.
By their numbers in this assay, from the lowest: compounds 4, 2, 3 and 1 (each within the scatter of the next).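

Exchanging 2-chlorophenyl for 3-chlorophenyl, with the same atoms joined differently, gives a 1.1-fold lower number from compound 3 to compound 4 (0.05 log units; within the scatter) in this assay, so the earlier finding that a chloro group can be carried here without a step beyond the scatter now covers both of these chlorophenyl groups. Chloro in place of fluoro gives a 1.1-fold lower number from compound 2 to compound 4 (0.04 log units; within the scatter), and chloro in place of hydrogen gives a 1.1-fold lower number from compound 1 to compound 4 (0.06 log units; within the scatter), which places compound 4 level with compounds 1, 2 and 3 and leaves all four readings impossible to tell apart on this scale. Nothing available here bears on why these readings stay level.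

The substituents shown on this aromatic ring are limited to fluoro and chloro, so it remains open whether an amine, a carboxylic acid or a longer chain in the same place would also stay within the scatter of these four compounds. From the compounds shown here alone, it also remains open whether 4-chlorophenyl would read level with 2-chlorophenyl and 3-chlorophenyl, and whether the same quiet picture would hold on the other parts of the shared core.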